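A few compounds are considered here, and "the series" means these few. Any claim that something is new, unique, unknown or untested is made for them only; others in the source may bear on it.

Compound 1 `CCOC(=O)C1=Cc2ccccc2OC1(OCc1cn(-c2ccc(C)cc2)nn1)C(F)(F)F` gives 26700 nM in a functional assay on MCF7 cells (Homo sapiens) for inhibition, read by MTT assay, with a stated time of 24 h; a higher number here means a weaker inhibitor, a lower number a stronger inhibitor.
Compound 2 `CCOC(=O)C1=Cc2ccccc2OC1(OCc1cn(-c2ccccc2)nn1)C(F)(F)F` gives > 150000 nM in this assay, which is a limit of the assay and not a number.
Compound 3 `CCCCCCCCn1cc(COC2(C(F)(F)F)Oc3ccccc3C=C2C(=O)OCC)nn1` gives > 150000 nM in this assay, again a limit and not a number.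

On the numbers shown, compound 3 therefore stands at the limit of > 150000 nM in this assay, at which 2 of the 3 values shown sit, with no value of its own. Compound 4 `CCOC(=O)C1=Cc2ccccc2OC1(OCc1cn(-c2ccc(F)c([N+](=O)[O-])c2)nn1)C(F)(F)F` differs from compound 3 in one place: 4-fluoro-3-nitrophenyl in place of octyl on an aromatic nitrogen.

For the measured compounds named here, two measured steps bear on this change. The step of an at least 5.6-fold higher number from compound 1 to compound 3 (0.74 log units; beyond the scatter) shows that an octyl chain on that nitrogen sits at least modestly weaker than a 4-methylphenyl. The step of an at least 5.6-fold higher number from compound 1 to compound 2 (0.74 log units; beyond the scatter) shows, however, that a plain phenyl on the same nitrogen also falls to the limit. The step that the two limits leave unreadable from compound 2 to compound 3 gives no readable size. Compound 4 returns an aryl group to that nitrogen, but a 4-fluoro-3-nitrophenyl rather than the 4-methylphenyl of compound 1, so a lower number than compound 3 is expected, of uncertain size; a limit remains possible. The estimated step is an at least 1.8-fold lower number from compound 3 to compound 4 (0.27 log units; that floor lies within the scatter). Compound 4 is expected at about 80000 nM, in a range from 20000 nM to 300000 nM.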

Compound 4, half-maximal inhibitory concentration: 16200 nM
The estimate for compound 4 lay 4.9-fold (0.69 log units) above the measured number, outside the stated range (below it).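

In this assay, a readable value on this aromatic nitrogen does not depend on the 4-methylphenyl group of compound 1, since the 4-fluoro-3-nitrophenyl group gives an at least 9.2-fold lower number from compound 3 to compound 4 (0.96 log units; beyond the scatter) and an at least 9.2-fold lower number from compound 2 to compound 4 (0.96 log units; beyond the scatter). Only a 1.6-fold lower number from compound 1 to compound 4 (0.22 log units; within the scatter) separates the two substituted phenyl groups, so they cannot be told apart here. Among the compounds shown, the two with a substituted phenyl group give numbers, while the plain phenyl of compound 2 and the octyl chain of compound 3 share a limit, which is not a number: the limit of > 150000 nM in this assay, at which 2 of the 4 values shown sit.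

The compounds shown leave open which part of the 4-fluoro-3-nitrophenyl group goes with the lower number, as neither a 4-fluorophenyl nor a 3-nitrophenyl group stands among them. They also leave open how an amine or a carboxylic acid on that phenyl ring, or a benzyl group on the same nitrogen, would read, and the steps to compound 4 from the two limits give only a floor for their size.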